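The compounds below may be only part of what the source reports. "The series", "measured", "known", "first", "only" and "open" are said of these compounds alone.

In an ADME assay on HELF cells (Homo sapiens) for cytotoxicity, with a stated time of 3 days (a lower number here means that less compound is tolerated, a higher number that more compound is tolerated), compound 1 `CC(C)C[C@H](NC(=O)[C@]1(Cc2ccccc2)CCN1C(=O)OCc1ccccc1)C(N)=O` gives 100000 nM, the only plain number among the three results shown. Compound 2 `C[C@H](NC(=O)[C@]1(Cc2ccccc2)CCN1S(=O)(=O)c1ccc2ccccc2c1)C(N)=O` gives > 100000 nM, which is a limit of the assay rather than a number. Compound 3 `CC(C)[C@H](NC(=O)[C@@]1(Cc2ccccc2)CCN1C(=O)OCc1ccccc1)C(N)=O` likewise gives > 100000 nM, again a limit and not a number. Compound 1 therefore sits right at the limit of > 100000 nM in this assay, at which 2 of the 3 values shown sit, so all three compounds are tolerated up to the highest concentration the assay resolves.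

Compound 4 `C[C@H](NC(=O)[C@]1(Cc2ccccc2)CCN1C(=O)OCc1ccccc1)C(=O)NC1CCCCC1` differs from compound 1 in one place: 1-(cyclohexylcarbamoyl)ethyl in place of 1-carbamoyl-3-methylbutyl on an amide-type nitrogen. Going by the values given here, no measured pair of compounds shares this change, so its size cannot be read from the data; with every result at the ceiling of this assay, the step is expected to be no change at the digits printed from compound 1 to compound 4 (within the scatter), no change beyond the scatter. Compound 4 is expected to give 100000 nM, between 50000 nM and 200000 nM.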

Compound 4, minimum cytotoxic concentration: > 100000 nM
Compound 4 ended at the assay's limit; the forecaster's own chance of this, stated with the estimate: 60%; the middle value sits exactly at the limit.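

In this assay, putting 1-(cyclohexylcarbamoyl)ethyl in place of 1-carbamoyl-3-methylbutyl on this amide-type nitrogen gives a number no lower from compound 1 to compound 4 (the limit leaves the size open). Compound 4 gives > 100000 nM, which is a limit of the assay and not a number. A group carrying a six-membered carbon ring is therefore tolerated at this position, and the results still do not separate the compounds: the limit of > 100000 nM in this assay, at which 3 of the 4 values shown sit.

As far as these compounds go, how far compound 4 lies beyond that limit stays open. So does the effect of an amine or a carboxylic acid on this amide-type nitrogen.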